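Aryl group on the ring nitrogen: compound 2 to compound 3

This account rests on a few compounds, and the source may have more. Where it says the series, first, only, none or still open, it means among the compounds named here.

Measured in a functional assay on A549 cells (Homo sapiens) for antiproliferative activity, read by MTT assay, with a stated time of 72 h; on this read-out lower numbers stand for stronger inhibition and higher numbers for weaker inhibition:
- compound 1 `C#Cc1cccc(Nc2ncnc3cc(OC)c(OCCCCC(=O)Nc4ccc(S(N)(=O)=O)cc4)cc23)c1`: 7720 nM
- compound 2 `COc1ccc(Nc2ncnc3cc(OC)c(OCCCCC(=O)Nc4ccc(S(N)(=O)=O)cc4)cc23)cc1OC`: > 40000 nM

Compound 2 sits only at a limit of this assay, the one given by the limit of > 40000 nM in this assay, at which 1 of the 2 values shown sits, so no number is known for it. Within the data shown here, the single measured step that touches the same position is an at least 5.1-fold higher number from compound 1 to compound 2 (0.71 log units; beyond the scatter), which shows that the 3,4-dimethoxyphenyl group of compound 2 gives a weaker result than the 3-ethynylphenyl group of compound 1.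

Compound 3 `COc1cc2ncnc(Nc3ccc(C)cc3)c2cc1OCCCCC(=O)Nc1ccc(S(N)(=O)=O)cc1` differs from compound 2 in that same place: 4-methylphenyl in place of 3,4-dimethoxyphenyl on a nitrogen on an aromatic ring. Among the measured compounds shown here, only the step from compound 1 to compound 2 bears on this, and it tells which way the 3,4-dimethoxyphenyl group moves the number but nothing direct about 4-methylphenyl. An improvement from compound 2 toward compound 1 is expected, but not the whole way, and a second limit remains possible.

For compound 3 the expected value in this assay is estimated at 20000 nM, with a range of 6000 nM to 60000 nM. That estimate means an expected step of an at least 2.0-fold lower number from compound 2 to compound 3 (0.30 log units; that floor lies within the scatter), toward stronger inhibition.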

Compound 3, half-maximal inhibitory concentration: > 40000 nM
Compound 3 gave a limit, no number; the forecaster's own chance of this, stated with the estimate: 35%; at least 2.0-fold (0.30 log units) between middle value and limit.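

In this assay, 4-methylphenyl in place of 3-ethynylphenyl on the nitrogen gives an at least 5.1-fold higher number from compound 1 to compound 3 (0.71 log units; beyond the scatter), so a second replacement at this position now falls beyond the scatter. Compound 1, at 7720 nM, remains the only one of the three with a number, and the loss no longer rests on 3,4-dimethoxyphenyl alone: 4-methylphenyl, which has no oxygen and no hydrogen-bond acceptors, also fails to reach a measurable value. The step between compound 2 and compound 3 cannot be read, and the two groups cannot be ranked, as both compounds give only the same limit: the limit of > 40000 nM in this assay, at which 2 of the 3 values shown sit.

From the compounds shown here alone, it remains open whether the ethynyl group itself or its place on the ring accounts for the measurable value of compound 1, and how an unsubstituted phenyl, a 3-chlorophenyl or a 4-ethynylphenyl group would read on this nitrogen. Also open, going by these compounds, is whether a longer chain or a carboxylic acid in place of the sulfonamide would shift any of these values.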